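The source may hold more compounds than are shown below. What is called first, only, known or untested is meant among the compounds shown, and "the series" means these compounds.

Of the compounds shown here, three of a shared core have been measured in a functional assay on cardiac atrium for agonist activity at histamine H2 receptor (Cavia porcellus); on this read-out lower numbers stand for lower potency and higher numbers for higher potency (the scale is a negative logarithm). Compound 1, with structure `N=C(NCCCc1c[nH]cn1)NCCSC(c1ccccc1)c1ccccn1`, gives 6.6 in this assay. Compound 2, with structure `Cc1ccc(C(CC/N=C(\N)NCCCc2c[nH]cn2)c2ccccn2)cc1`, gives 7.71. Compound 3, with structure `N=C(NCCCc1c[nH]cn1)NCCC(c1ccc(F)cc1)c1ccccn1`, gives 8.01, the highest of the three numbers. The gap between compound 3 and compound 2 lies within the usual scatter of repeated measurements, so the two cannot be placed in an order; the gap between compound 3 and compound 1 lies beyond it, so compound 3 is clearly more potent than compound 1.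

Compound 4, with structure `N=C(NCCCc1c[nH]cn1)NCCC(c1ccc(Cl)c(Cl)c1)c1ccccn1`, has not yet been measured. It differs from compound 3 in one place: 3,4-dichlorophenyl in place of 4-fluorophenyl on a saturated chain carbon bound to an aromatic carbon and a saturated chain carbon. Among the compounds with values here, no pair of measured compounds shows this particular change, so its effect on this assay is not known from the data at hand. With compound 2 at 7.71 and compound 3 at 8.01 differing only within the scatter despite a different group at this position, the step from compound 3 to compound 4 is expected to be small, a number 0.11 log units lower from compound 3 to compound 4 (within the scatter), and not clearly beyond the scatter in either direction. Compound 4 is therefore estimated at 7.9, within a range from 7.3 to 8.5.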

Compound 4, negative logarithm of the half-maximal effective concentration: 8.19
Compound 4: the middle estimate sits 0.29 log units below what was measured; the measured number falls inside the stated range.
By their numbers in this assay, from the lowest: compound 1; then compounds 2, 3 and 4 (each within the scatter of the next, the first and the last beyond it).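

Swapping 4-fluorophenyl for 3,4-dichlorophenyl on a saturated chain carbon bound to an aromatic carbon and a saturated chain carbon gives the first direct comparison at this position in this assay: a number 0.18 log units higher from compound 3 to compound 4 (within the scatter), so the two compounds cannot be placed in an order. For this one pair, then, the position accepts a group of eight heavy atoms with two chlorines in place of one of seven heavy atoms with a single fluorine, and the read-out shows no clear change. Nothing measured here explains this outcome.

From the compounds shown here alone, it remains open how far this tolerance extends, for example whether a plain phenyl, or a phenyl carrying an amine or a carboxylic acid, would give a similar number in this assay at this position. A single step also cannot separate the contribution of each chlorine, which would take a comparison with a phenyl ring carrying only one chlorine.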